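Acetyl to Dimethylamino: Forecasting a Cytotoxicity Step

The source may report more compounds than this note shows. Statements on the series, on what has been measured and on what is new or still open speak of the compounds shown alone.

Three compounds share one core. Compound 1 `COc1cc(C)cc(-c2c(-c3ccnc(-c4ccc(C(C)=O)cc4)c3)cnn2CC#N)c1` gives 98% in a functional assay on SF-539 cells (Homo sapiens) for cytotoxicity, read by sulforhodamine B assay, with a stated time of 48 h, tested at 0.01 uM (a higher number here means a weaker effect of the compound at the concentration tested, a lower number a stronger effect), the highest of the three numbers. Compound 2 `COc1cc(C)cc(-c2nn(CC#N)cc2-c2ccc(-c3cccc(C(C)=O)c3)nc2)c1` gives 89% in this assay, and compound 3 `Cc1cc(O)cc(-c2nn(CC#N)cc2-c2ccnc(-c3ccc(Oc4ccccc4)cc3)c2)c1` gives 88% there; both lie within the scatter of compound 1, so no order can be read among the three. The change toward compound 4 `COc1cc(C)cc(-c2c(-c3ccnc(-c4ccc(N(C)C)cc4)c3)cnn2CC#N)c1` is dimethylamino in place of acetyl on an aromatic carbon, para to a large group on a six-membered aromatic ring of carbon only. For the measured compounds named here, no measured pair isolates this change, so the expectation rests on the narrow band of the three numbers. Compound 4 is expected to show a number 4 percentage points lower from compound 1 to compound 4 (within the scatter), nothing beyond the scatter. Compound 4 is therefore estimated at 94%, between 80% and 105%.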

Compound 4, a percentage reported as activity, at one concentration (the size of the read-out at that concentration, not a potency): 79%
Beside the measured number, compound 4's estimate is 15 percentage points above it; measured number below the stated range.
By their numbers in this assay, from the lowest: compounds 4, 3, 2 and 1 (each within the scatter of the next, the first and the last beyond it).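

On the 4-acetylphenyl group of compound 1, the change to 4-(dimethylamino)phenyl moves the read-out in this assay, giving a number 19 percentage points lower from compound 1 to compound 4 (beyond the scatter). For the compounds shown here, the earlier compounds offered no pair differing in one place, so this is the first sign that this position can alter the effect at the concentration tested. Nothing measured here explains the step.

As far as these compounds go, whether a primary amine, a carboxylic acid or a methoxy group on the same aromatic carbon would shift the number further remains open. Also open, from the compounds shown here alone, is whether the step would recur on a different arrangement of the shared core.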